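The compounds below may be only part of what the source reports. "The series", "measured", "known", "first", "only" and "open" are said of these compounds alone.

Working notes on the series. In a functional assay on KG-1 cells (Homo sapiens) for cytotoxicity, read by luminescence and CellTiter-Glo, with a stated time of 3 days (a lower number here means a stronger inhibitor, a higher number a weaker inhibitor), compound 1 `O=C(Nc1cc(C(F)(F)F)cc(C(F)(F)F)c1)c1cc(Br)c(-c2ccccc2)cc1O` gives 300 nM, while compound 2 `N#Cc1ccc(NC(=O)c2ccc(-c3cccnc3)cc2O)cc1` gives 7940 nM. Compound 2 has the higher of these two numbers, and its gap to compound 1 lies beyond the scatter. Compound 3 `N#Cc1ccc(NC(=O)c2c(O)cccc2F)cc1` gives only a limit, > 10000 nM. Compound 2 therefore stands at the weak end of the numeric values, with one further compound reported only as a limit.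

The next compound is compound 4 `N#Cc1ccc(NC(=O)c2ccc(F)cc2O)cc1`, which has fluoro in place of pyridin-3-yl on an aromatic carbon relative to compound 2: fluoro in place of pyridin-3-yl on an aromatic carbon. Among the measured compounds shown here, no measured pair differs in one place, so the expectation rests on few data. Compound 4 shares the fluoro, hydroxy and nitrile groups with compound 3, whose reading in this assay is the limit > 10000 nM. On that comparison, the expected step is toward a higher number but small, probably not beyond the scatter, and the assay may well report only a limit. The estimated change is a 1.4-fold higher number from compound 2 to compound 4 (0.14 log units; within the scatter). For compound 4 the expected value is 11000 nM, with an estimated range of 4500 nM to 30000 nM.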

Compound 4, half-maximal inhibitory concentration: 3150 nM
The estimate for compound 4 lay 3.5-fold (0.54 log units) above the measured number; measured number outside the range, below it.
By their numbers in this assay, from the lowest: compound 1; then compound 4; then compound 2. At a limit, above all of these: compound 3.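

In this assay, among the compounds shown here, putting fluoro in place of pyridin-3-yl on the aromatic carbon meta to a hydroxy group and para to a large group gives a 2.5-fold lower number from compound 2 to compound 4 (0.40 log units; beyond the scatter), the first step that can be read at a single place. A reading at this position therefore does not depend on the six-membered aromatic ring of pyridin-3-yl or on its hydrogen-bond acceptor: fluoro, which carries neither, gives a lower number, although the step is only modest. Compound 4 gives a number rather than a limit, and the only compound reported as a limit is compound 3: the limit of > 10000 nM in this assay, at which 1 of the 4 values shown sits.

A single step cannot separate the loss of pyridin-3-yl from the arrival of fluoro, and plain hydrogen, methoxy or an amine on the same carbon would be needed to tell these apart. Compound 1, at 300 nM, differs from compound 4 in more than one place, so its lower number cannot be assigned to this position.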